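3-Methylphenyl Replaces 4-Fluorophenyl on the Saturated Ring Carbon

A few compounds are considered here, and "the series" means these few. Any claim that something is new, unique, unknown or untested is made for them only; others in the source may bear on it.

Of the compounds shown here, three sharing one core have been measured, and a fourth waits. Compound 1 `NS(=O)(=O)c1ccc(N2N=C(c3ccc(OCc4ccccc4)cc3)CC2c2ccccc2)cc1` was tested in an ADME assay on MT4 cells (Homo sapiens) for cytotoxicity, read by MTT assay, with a stated time of 96 h; a lower number here means that less compound is tolerated, a higher number that more compound is tolerated; in that test compound 1 gives > 100000 nM, which is a limit of the assay rather than a number. Compound 2 `NS(=O)(=O)c1ccc(N2N=C(c3ccc(OCc4ccccc4)cc3)CC2c2ccc(F)cc2)cc1` also reaches only a limit in this assay, giving > 100000 nM. Compound 3 `NS(=O)(=O)c1ccc(N2N=C(c3ccc(Oc4ccccc4)cc3)CC2c2ccc(F)cc2)cc1` gives 33000 nM in this assay. The step that the two limits leave unreadable from compound 1 to compound 2 cannot be sized because both values sit at the limit of > 100000 nM in this assay, at which 2 of the 3 values shown sit. The step of an at least 3.0-fold lower number from compound 2 to compound 3 (0.48 log units; beyond the scatter) came from changing the group on the oxygen. Compound 2 therefore stands at the limit, as one of two such values, with only compound 3 giving a number.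

Compound 4 `Cc1cccc(C2CC(c3ccc(OCc4ccccc4)cc3)=NN2c2ccc(S(N)(=O)=O)cc2)c1` differs from compound 2 by 3-methylphenyl in place of 4-fluorophenyl on a saturated ring carbon. Within the data shown here, the only measured step at this saturated ring carbon is a step that the two limits leave unreadable from compound 1 to compound 2, which has no readable size; the step of an at least 3.0-fold lower number from compound 2 to compound 3 (0.48 log units; beyond the scatter) concerns a different place. Among the measured compounds shown here, no measured step therefore points to a change beyond the scatter, and compound 4 is expected to stay near the limit in this assay, a step of a number no higher from compound 2 to compound 4 (the limit leaves the size open). For compound 4 the estimated value is 100000 nM, with a range from 40000 nM to 200000 nM.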

Compound 4, half-maximal cytotoxic concentration: 44000 nM
Compound 4: middle estimate off by 2.3-fold (0.36 log units), on the high side, and the stated range covers the measured number.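

Among these compounds, on the saturated ring carbon, the aromatic group does change the reading: 3-methylphenyl gives an at least 2.2-fold lower number from compound 2 to compound 4 (0.35 log units; beyond the scatter) in this assay and so provides the first sized step at this place, where the earlier step could not be read. Methyl in place of hydrogen on the aromatic carbon gives an at least 2.2-fold lower number from compound 1 to compound 4 (0.35 log units; beyond the scatter) as well, so one added methyl is enough to go beyond the scatter. Both sizes are only minimums, because compound 1 and compound 2 give no exact number: the limit of > 100000 nM in this assay, at which 2 of the 4 values shown sit.

The compounds shown leave open how the number would respond to another group on this aromatic ring, such as a methoxy, an amine or a carboxylic acid. They also leave open whether 3-methylphenyl would lower the number in the same way alongside the phenyl on the oxygen of compound 3.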